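The compounds below may be only part of what the source reports. "The series", "measured", "known", "first", "only" and "open" are said of these compounds alone.

In a functional assay on CEM-SS cells (Homo sapiens) for inhibition, read by thymidine incorporation (a higher number here means that more compound is tolerated, a lower number that less compound is tolerated), compound 1 (`CC(Cn1c(S)nc2ccccc21)NCc1ccccc1`) gives 82000 nM. Compound 3 (`CC(C)=CCNC(C)Cn1c(S)nc2ccccc21`) gives 81000 nM, a number that cannot be told apart from that of compound 1. Compound 2 (`C=CCNC(C)Cn1c(S)nc2ccccc21`) is reported only as a limit of the assay, > 100000 nM. Among the measured compounds shown here, compound 1 thus stands level with compound 3, and its only other neighbour has a limit rather than a number.

Compound 4 (`CC(Cn1c(S)nc2ccccc21)N(C)Cc1ccccc1`) differs from compound 1 at the amine nitrogen: methyl in place of hydrogen on an amine nitrogen. Methyl takes the place of hydrogen there, and no measured step makes this change. The closest evidence comes from two steps on a saturated chain carbon bound to an amine nitrogen. Vinyl in place of phenyl gives an at least 1.2-fold higher number from compound 1 to compound 2 (0.08 log units; that floor lies within the scatter), and 2-methylprop-1-en-1-yl in place of phenyl gives a 1.0-fold lower number from compound 1 to compound 3 (0.01 log units; within the scatter). Neither step moves the number beyond the scatter, though neither replaces the hydrogen on the amine nitrogen, so they offer only indirect guidance. In this assay, no step beyond the scatter is expected in either direction. The expected result is a 1.2-fold lower number from compound 1 to compound 4 (0.07 log units; within the scatter). For compound 4 the estimate is 70000 nM, with an expected range of 30000 nM to 100000 nM.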

Compound 4, half-maximal cytotoxic concentration: 79000 nM
Compound 4: middle estimate off by 1.1-fold (0.05 log units), on the low side; low and high end bracket the measured number.
By their numbers in this assay, from the lowest: compounds 4, 3 and 1 (each within the scatter of the next). At a limit, above all of these: compound 2.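

In this assay, compound 4 is the first compound shown in which the amine nitrogen itself changes, whereas the earlier steps varied only the group on a saturated chain carbon bound to that nitrogen. Methyl in place of hydrogen on this amine nitrogen gives a 1.0-fold lower number from compound 1 to compound 4 (0.02 log units; within the scatter), so the hydrogen there is not needed to keep the number at the level of compound 1, and the change leaves no mark that can be told from the scatter. Compound 2 alone stands at a limit of the assay, so the compounds shown give little room to read any rise in the number, and a rise past that limit could not be sized: the limit of > 100000 nM in this assay, at which 1 of the 4 values shown sits.

The compounds shown leave open whether anything larger than methyl on this amine nitrogen, such as an ethyl group, a longer chain or an acetyl group, would also leave the number in place. They also leave open whether a carboxylic acid on a chain at this nitrogen would move the number beyond the scatter in either direction, since methyl is the only group shown to replace the hydrogen here.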